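An acetyl swap in a series held at a limit

A few compounds are considered here, and "the series" means these few. Any claim that something is new, unique, unknown or untested is made for them only; others in the source may bear on it.

Measured so far in a functional assay on SK-BR-3 cells (Homo sapiens) for cytotoxicity, read by MTT assay, with a stated time of 72 h (a lower number here means that less compound is needed, a higher number that more compound is needed for the effect), for each compound
Compound 1 `CCc1cccc2c(OC)c(-c3occ(C)c3C(=O)NC)ccc12` gives > 10 ug/mL
Compound 2 `CCc1cccc2c(OC)c(-c3occ(C)c3COC)ccc12` gives > 10 ug/mL
Compound 3 `CCOCc1c(C)coc1-c1ccc2c(CC)cccc2c1OC` gives > 10 ug/mL

Compound 3 gives only the limit > 10 ug/mL in this assay and no number. The series as a whole offers the limit of > 10 ug/mL in this assay, at which 3 of the 3 values shown sit, and nothing firmer. Compound 4 `CCc1cccc2c(OC)c(-c3occ(C)c3COC(C)=O)ccc12` carries acetyl in place of ethyl on an oxygen on a saturated carbon and otherwise matches compound 3. Within the data shown here, three measured steps bear on this change: a step that the two limits leave unreadable from compound 1 to compound 2 and a step that the two limits leave unreadable from compound 1 to compound 3 and also a step that the two limits leave unreadable from compound 2 to compound 3 among the same compounds. None has a readable size, so they give no direction and no step beyond the scatter is expected. A further limit remains the likeliest report. The expected change is a step that the limit leaves unreadable from compound 3 to compound 4 on this estimate. Expected for compound 4 is 12 ug/mL with 5 ug/mL to 30 ug/mL as its range.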

Compound 4, concentration for half-maximal effect: > 10 ug/mL
Compound 4 gave a limit, no number; the forecaster's own chance of this, stated with the estimate: 70%; the middle value does not contradict the limit.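

Among these compounds, no step from compound 1, compound 2 or compound 3 to compound 4 can be read, since all four values are limits: the limit of > 10 ug/mL in this assay, at which 4 of the 4 values shown sit.

The compounds shown leave open what concentration any of them needs, and whether acetoxymethyl and ethoxymethyl differ at all.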